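This account rests on a few compounds, and the source may have more. Where it says the series, first, only, none or still open, it means among the compounds named here.

Working notes on the series.

Compound 1 `CNC(=O)c1cc(Oc2ccc(NC(=O)c3cc(-c4ccc(F)cc4)ncn3)cc2F)ccn1` is the reference point for the step followed here. In a functional assay on PC-3 cells (Homo sapiens) for cytotoxicity, read by MTT assay, with a stated time of 72 h (a higher number here means a weaker inhibitor, a lower number a stronger inhibitor), compound 1 gives > 100000 nM, which is a limit of the assay and not a number. That value sits at the limit of > 100000 nM in this assay, at which 1 of the 3 values shown sits. Compound 2 `CNC(=O)c1cc(Oc2ccc(NC(=O)c3nccc(-c4ccccc4)n3)cc2)ccn1` gives 7310 nM in this assay. Compound 3 `CNC(=O)c1cc(Oc2ccc(NC(=O)c3nccc(-c4ccc(OC)cc4)n3)cc2F)ccn1` gives 24300 nM in this assay. Among the measured compounds shown here, the core of compound 1 differs from the core shared by compound 2 and compound 3, and no single-change step connects them to compound 1, so the two values of compound 2 and compound 3 show only that members of this set can register a number in this assay while compound 1 registers only a limit.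

Compound 4 `CNC(=O)c1cc(Oc2ccc(NC(=O)c3cc(-c4ccc(C)cc4)ncn3)cc2F)ccn1` has not yet been measured. It differs from compound 1 by methyl in place of fluoro on an aromatic carbon. This is a small exchange at the outer edge of the molecule, and with compound 1 already at a limit, the expected step in this assay from compound 1 to compound 4 is none beyond the scatter, in either direction. Compound 4 is therefore expected at 100000 nM, with a range from 30000 nM to 300000 nM. The estimated step from compound 1 to compound 4 of a number no higher from compound 1 to compound 4 (the limit leaves the size open) means that a second limit is the more likely outcome.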

Compound 4, half-maximal inhibitory concentration: 40200 nM
The estimate for compound 4 lay 2.5-fold (0.40 log units) above the measured number; low and high end bracket the measured number.
By their numbers in this assay, from the lowest: compound 2; then compounds 3 and 4 (each within the scatter of the next). At a limit, above all of these: compound 1.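

In this assay, the change from 4-fluorophenyl to 4-methylphenyl, on an aromatic carbon para to a large group, gives an at least 2.4-fold lower number from compound 1 to compound 4 (0.39 log units; beyond the scatter). Among the compounds shown here, this shows for the first time that the core of compound 1 can register a number in this assay, and that a single exchange at this outer position is enough to move a compound off the limit. Compound 1 gives > 100000 nM, which is a limit of the assay and not a number, and the full size of the step stays open because the starting point is a limit: the limit of > 100000 nM in this assay, at which 1 of the 4 values shown sits.

The compounds shown carry only fluoro and methyl at this position of this core, so it remains open whether the change belongs to methyl alone or would extend to an amine, a carboxylic acid or a longer alkyl chain in the same place. For the compounds shown here, no single-change step links compound 4 to compound 2 or compound 3, so whether the same exchange would move a value on their core also remains open.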